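Swapping the amide substituent on a shared aminothiophene core

The source may hold more compounds than are shown below. What is called first, only, known or untested is meant among the compounds shown, and "the series" means these compounds.

Of the compounds shown here, three built on one shared core have been measured in a functional assay on PC-3 cells (Homo sapiens) for cytotoxicity, read by sulforhodamine B assay, with a stated time of 72 h; on this read-out higher numbers stand for weaker inhibition and lower numbers for stronger inhibition. Compound 1, `Nc1sc(-c2ccccc2)c(-c2ccc(Cl)cc2)c1C(=O)NCc1ccccc1`, gives 22800 nM in this assay. Compound 2, `Nc1sc(-c2ccc(F)cc2)c(-c2ccc(Cl)cc2)c1C(=O)NC1CC1`, gives 28000 nM, and compound 3, `Nc1sc(-c2ccc(F)cc2)c(-c2ccc(Cl)cc2)c1C(=O)N1CCCC1`, gives 20400 nM. For the measured compounds named here, compound 3 has the smallest of the three numbers, yet the one computed step that reaches it, a 1.4-fold lower number from compound 2 to compound 3 (0.14 log units; within the scatter), lies within the scatter, and compound 1 sits closer still, so the three compounds cannot be told apart on these numbers.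

Compound 4, `Nc1sc(-c2ccc(F)cc2)c(-c2ccc(Cl)cc2)c1C(=O)NCc1ccccc1`, is the next compound, and it differs from compound 3 by one change: benzylamino in place of pyrrolidin-1-yl on a carbonyl carbon. Going by the values given here, only one measured step touches this same position, the exchange of cyclopropylamino for pyrrolidin-1-yl, a 1.4-fold lower number from compound 2 to compound 3 (0.14 log units; within the scatter), and it stayed within the scatter. Compound 1 already carries the benzylamino group on an otherwise closely related core and gives 22800 nM, a number in the same region as compound 3. On this evidence no step beyond the scatter is expected in this assay, and the expected step for compound 4 is a 1.1-fold higher number from compound 3 to compound 4 (0.03 log units; within the scatter). Compound 4 is therefore estimated at 22000 nM in this assay, with a range from 11000 nM to 45000 nM.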

Compound 4, half-maximal inhibitory concentration: 25800 nM
Beside the measured number, compound 4's estimate is 1.2-fold (0.07 log units) below it, and the stated range covers the measured number.
By their numbers in this assay, from the lowest: compounds 3, 1, 4 and 2 (each within the scatter of the next).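

For the compounds shown here, the new steps show that this position tolerates more variety than the single earlier step could reveal: in this assay, benzylamino in place of pyrrolidin-1-yl on a carbonyl carbon gives a 1.3-fold higher number from compound 3 to compound 4 (0.10 log units; within the scatter), and benzyl in place of cyclopropyl on an amide-type nitrogen gives a 1.1-fold lower number from compound 2 to compound 4 (0.04 log units; within the scatter). Cyclopropylamino, pyrrolidin-1-yl and benzylamino can therefore not be told apart here, even though the swap from pyrrolidin-1-yl to benzylamino brings in an aromatic ring and a hydrogen-bond donor. A second position also comes into view, since fluoro in place of hydrogen on an aromatic carbon gives a 1.1-fold higher number from compound 1 to compound 4 (0.05 log units; within the scatter), again within the scatter, and no further measurement is available to explain why these numbers stay so close.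

The compounds shown leave open whether any group on this carbonyl carbon can shift the number beyond the scatter, for instance a carboxylic acid or an amine carried on a longer chain. They also leave open whether the same flat picture would hold for other groups on the aromatic ring that carries the fluoro, such as methoxy.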